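Hydroxy in place of methyl on compound 1

The compounds below may be only part of what the source reports. "The series", "measured", "known", "first", "only" and "open" are said of these compounds alone.

Among the measured compounds shown here, in a functional assay on HOS cells (Homo sapiens) for antiproliferative activity, read by sulforhodamine B assay (on this read-out higher numbers stand for weaker inhibition of growth and lower numbers for stronger inhibition of growth), compound 1 `CC[C@@H]1O[C@H](COCc2ccccc2)[C@@H](OCc2ccccc2)[C@H](OCc2ccccc2)[C@H]1O` gives 34200 nM, the only actual number so far. Compound 2 `CC[C@@H]1O[C@H](COCc2ccccc2)[C@@H](OCc2ccccc2)[C@H](OCc2ccccc2)[C@H]1OC(C)=O` gives > 50000 nM, which is a limit. For the measured compounds named here, the sole measured step, an at least 1.4-fold higher number from compound 1 to compound 2 (0.16 log units; that floor lies within the scatter), is a different change and offers only weak guidance. Compound 3 `OC[C@@H]1O[C@H](COCc2ccccc2)[C@@H](OCc2ccccc2)[C@H](OCc2ccccc2)[C@H]1O` carries hydroxy in place of methyl on a saturated chain carbon bound to a saturated ring carbon, with hydroxy in place of methyl on a saturated chain carbon bound to a saturated ring carbon. No step beyond the scatter is therefore expected in this assay, and the expected step is a 1.0-fold higher number from compound 1 to compound 3 (0.01 log units; within the scatter). For compound 3 the estimated value is 35000 nM, with an expected range of 15000 nM to 70000 nM.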

Compound 3, concentration for 50% growth inhibition: 27300 nM
Compound 3: middle estimate off by 1.3-fold (0.11 log units), on the high side; the range from low to high includes it.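

In this assay, hydroxy in place of methyl on a saturated chain carbon bound to a saturated ring carbon gives a 1.3-fold lower number from compound 1 to compound 3 (0.10 log units; within the scatter). At this position, ethyl to hydroxymethyl, with a hydrogen-bond donor and acceptor entering, therefore produces no step beyond the scatter. Compound 2, changed at a different place, is held at a limit of the assay: the limit of > 50000 nM in this assay, at which 1 of the 3 values shown sits.

Going by these compounds, whether an amine, a carboxylic acid or a longer chain at this position would move the number beyond the scatter remains open. So does whether any change on the core of compound 1 would do so.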